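A few compounds are considered here, and "the series" means these few. Any claim that something is new, unique, unknown or untested is made for them only; others in the source may bear on it.

In a functional assay with Homo sapiens as the target (on this read-out higher numbers stand for weaker inhibition and lower numbers for stronger inhibition), compound 1 `CC(C)[C@H](NC(=O)COc1cccc2ccccc12)C(=O)N[C@@H](CC(=O)O)C(=O)COc1cccc2ccccc12` gives 19000 nM, and compound 2 `CC(C)[C@H](NC(=O)COc1cccc2ccccc12)C(=O)N[C@@H](CC(=O)O)C(=O)COc1cccc(C(F)(F)F)c1` gives 16600 nM. These two values lie within the scatter of each other, so compound 2 holds no separate rank. Compound 3 `CC(C)[C@H](NC(=O)COc1cccc2ccccc12)C(=O)N[C@@H](CC(=O)O)C(=O)COc1ccccc1[N+](=O)[O-]` has not yet been measured. It keeps the core of compound 2 and changes only the aryl group: 2-nitrophenyl in place of 3-(trifluoromethyl)phenyl on an oxygen on a saturated carbon. Thus 2-nitrophenyl stands in place of 3-(trifluoromethyl)phenyl on an oxygen on a saturated carbon.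

Among the measured compounds shown here, only one measured step bears on this change. At the same place, naphthalen-1-yl gave way to 3-(trifluoromethyl)phenyl, and the result was a 1.1-fold lower number from compound 1 to compound 2 (0.06 log units; within the scatter). That single step is thin evidence, and neither measured compound carries a 2-nitrophenyl group, so the range must stay generous. Even so, with that step as the only guide, no shift beyond the scatter is expected in this assay. The expected step is a 1.0-fold higher number from compound 2 to compound 3 (0.01 log units; within the scatter). For compound 3 the estimated value is 17000 nM, with an expected range from 7500 nM to 38000 nM.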

Compound 3, half-maximal inhibitory concentration: 27700 nM
Beside the measured number, compound 3's estimate is 1.6-fold (0.21 log units) below it; the range from low to high includes it.
By their numbers in this assay, from the lowest: compounds 2, 1 and 3 (each within the scatter of the next).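

In this assay, a third aryl group on this oxygen gives no separable result: the change to 2-nitrophenyl reads a 1.7-fold higher number from compound 2 to compound 3 (0.22 log units; within the scatter), and measured against naphthalen-1-yl it reads a 1.5-fold higher number from compound 1 to compound 3 (0.16 log units; within the scatter). Until now only naphthalen-1-yl and 3-(trifluoromethyl)phenyl had been compared here, and neither has any hydrogen-bond acceptors, whereas 2-nitrophenyl brings 2 hydrogen-bond acceptors and still stays within the scatter of both, so across these three compounds the read-out does not separate the groups. No other data bear on these numbers, so nothing can be said about what lies behind them.

Going by these compounds, all three compounds carry a six-membered aromatic ring of carbon on this oxygen and share the same remaining structure, so it remains open whether a ring bearing an amine or a carboxylic acid, or a saturated alkyl chain in place of the ring, would move the number beyond the scatter. The naphthalen-1-yl group at the other end of the shared core also stays the same throughout, so these compounds say nothing about changes there.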